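Chloro for methyl on the anilide of compound 2

The source may hold more compounds than are shown below. What is called first, only, known or untested is meant among the compounds shown, and "the series" means these compounds.

Within the data shown here, compound 2 `COc1cc2c(Nc3nc4ccc(C(=O)Nc5c(C)cccc5C)cc4s3)ncnc2cc1OCCCN1CCC(C)CC1` gives 72300 nM in a functional assay on NCI-H661 cells (Homo sapiens) for cytotoxicity, read by WST assay, with a stated time of 72 h (on this read-out higher numbers stand for weaker inhibition and lower numbers for stronger inhibition), the higher of the two numbers so far; its nearest neighbour, compound 1 `CCN(CC)CCCOc1cc2ncnc(Nc3nc4ccc(C(=O)Nc5c(C)cccc5C)cc4s3)c2cc1OC`, gives 66500 nM. Among the measured compounds shown here, the single measured step, a 1.1-fold higher number from compound 1 to compound 2 (0.04 log units; within the scatter), concerns the chain amine, not the anilide. Compound 3 `COc1cc2c(Nc3nc4ccc(C(=O)Nc5c(C)cccc5Cl)cc4s3)ncnc2cc1OCCCN1CCC(C)CC1` differs from compound 2 by chloro in place of methyl on an aromatic carbon. For the measured compounds named here, no measured step bears on this position, so in this assay a change of a 1.0-fold lower number from compound 2 to compound 3 (0.01 log units; within the scatter) is expected, nothing beyond the scatter. Compound 3 is estimated at 70000 nM, with a range of 25000 nM to 200000 nM.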

Compound 3, half-maximal inhibitory concentration: 7900 nM
Estimate against measurement, compound 3: 8.9-fold (0.95 log units) above, outside the stated range (below it).
By their numbers in this assay, from the lowest: compound 3; then compounds 1 and 2 (each within the scatter of the next).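

In this assay, replacing one methyl of the 2,6-dimethylphenyl group with chloro gives a 9.2-fold lower number from compound 2 to compound 3 (0.96 log units; beyond the scatter) and is the only listed step beyond the scatter. The anilide aryl group is therefore a position where a single-atom change moves this read-out, whereas the chain amine change gave a 1.1-fold higher number from compound 1 to compound 2 (0.04 log units; within the scatter) and stayed within the scatter. Nothing available accounts for the size of this step.

As far as these compounds go, whether fluoro, bromo or methoxy in place of this chloro would give a similar number remains open. Also open, from the compounds shown here alone, are the effect of a 2,6-dichlorophenyl group and whether the step carries over to the diethylamino chain of compound 1.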